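The compounds below may be only part of what the source reports. "The series", "measured", "known", "first", "only" and "open" are said of these compounds alone.

Compound 3 `COC(=O)c1sc2cc(C#Cc3ccsc3)cnc2c1N` carries the only numeric result in the set: in a functional assay on MCF7 cells (Homo sapiens) for inhibition, read by sulforhodamine B assay, with a stated time of 48 h (on this read-out higher numbers stand for weaker inhibition of growth and lower numbers for stronger inhibition of growth), compound 3 gives 27700 nM. Compound 1 `COC(=O)c1sc2cc(C#Cc3ccccc3F)cnc2c1N` gives only a limit of the assay, > 150000 nM, in this assay. Compound 2 `COC(=O)c1sc2cc(C#Cc3cccnc3)cnc2c1N` likewise gives only a limit, > 150000 nM, in this assay. Because the limit of > 150000 nM in this assay, at which 2 of the 3 values shown sit, caps two of the three values, the steps onto compound 3 are readable only as bounds: an at least 5.4-fold lower number from compound 1 to compound 3 (0.73 log units; beyond the scatter) and an at least 5.4-fold lower number from compound 2 to compound 3 (0.73 log units; beyond the scatter), while a step that the two limits leave unreadable from compound 1 to compound 2. The next change, (2-aminophenyl in place of thiophen-3-yl on a triple-bonded carbon), gives compound 4 `COC(=O)c1sc2cc(C#Cc3ccccc3N)cnc2c1N`. The step from compound 3 to compound 4 exchanges the five-membered ring for a six-membered aromatic ring of carbon only, as in compound 1 and compound 2, which both sit at the limit, and the steps from those two to compound 3 were at least modest in favour of compound 3. A step back of roughly that order, towards weaker inhibition of growth in this assay, is therefore expected, a 2.9-fold higher number from compound 3 to compound 4 (0.46 log units; beyond the scatter). Compound 4 is estimated at 80000 nM, within 20000 nM to 300000 nM, with a fair chance that only a limit is reported.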

Compound 4, concentration for 50% growth inhibition: 4100 nM
Compound 4: the middle estimate sits 20-fold (1.29 log units) above what was measured; measured number below the stated range.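

At the group on the triple-bonded carbon, a six-membered aromatic ring of carbon only does not by itself go with weak inhibition of growth in this assay, since 2-aminophenyl in place of thiophen-3-yl gives a 6.8-fold lower number from compound 3 to compound 4 (0.83 log units; beyond the scatter) in this series. Amino in place of fluoro on an aromatic carbon, with the ring otherwise kept, gives an at least 36-fold lower number from compound 1 to compound 4 (1.56 log units; beyond the scatter) on that single exchange, and 2-aminophenyl in place of pyridin-3-yl gives an at least 36-fold lower number from compound 2 to compound 4 (1.56 log units; beyond the scatter) on the ring as a whole. These last two steps are bounds and not sizes: the limit of > 150000 nM in this assay, at which 2 of the 4 values shown sit.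

The compounds shown do not separate the amino group from the ring that carries it, as they include no plain phenyl, hydroxyphenyl or acetamidophenyl group. Also open, from the compounds shown here alone, is how a carboxylic acid or an amide in place of the methyl ester would read.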